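A few compounds are considered here, and "the series" means these few. Any claim that something is new, unique, unknown or untested is made for them only; others in the source may bear on it.

Within the data shown here, compound 1 `C=C(C)C(=O)N(Cc1ccc(OC)c(O)c1)c1cc(OC)c(OC)c(OC)c1` is the only compound here with a measured number. In a functional assay on KYSE-450 cells (Homo sapiens) for inhibition, read by MTT assay, with a stated time of 48 h (a lower number here means a stronger inhibitor, a higher number a weaker inhibitor), compound 1 gives 200 nM. Compound 2 `COc1cc(NCc2ccc(Br)cc2)cc(OC)c1OC` is a related compound recorded only as a limit: in this assay compound 2 gives > 80000 nM, which is a limit of the assay and not a number, the same limit described as the limit of > 80000 nM in this assay, at which 1 of the 2 values shown sits. One of the two recorded values is a limit. Among the measured compounds shown here, no step between measured compounds can be stated, and compound 1 stands alone as the single stated number. Compound 3 `COc1ccc(CN(C(=O)CCCl)c2cc(OC)c(OC)c(OC)c2)cc1O` has not yet been measured. It differs from compound 1 in one place: 2-chloroethyl in place of 1-methylethenyl on a carbonyl carbon. The group that leaves carries a double bond outside aromatic rings; the group that enters carries a chlorine and no such double bond. For the measured compounds named here, with no measured step to lean on, the step from compound 1 to compound 3 is expected to be modest and toward weaker inhibition, as a 3.0-fold higher number from compound 1 to compound 3 (0.48 log units; beyond the scatter). For compound 3 in this assay the expected value is 600 nM, with a range from 150 nM to 3000 nM.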

Compound 3, half-maximal inhibitory concentration: 110 nM
Estimate against measurement, compound 3: 5.5-fold (0.74 log units) above; measured number outside the range, below it.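

In this assay the change from 1-methylethenyl to 2-chloroethyl on the carbonyl carbon gives a 1.8-fold lower number from compound 1 to compound 3 (0.26 log units; within the scatter) and so leaves the two compounds indistinguishable at this position. The double bond outside aromatic rings that 1-methylethenyl carries is therefore not required for a value in this range, at least in this one cell assay: 2-chloroethyl has no such double bond and carries a chlorine instead, and the result is the same within the scatter. Nothing measured here explains this sameness, and the one limit on record belongs to a compound that differs in more than one place, so it does not bear on this step.

Still open, going by these compounds, is how much freedom this position really allows, for instance whether a plain ethyl group with no chlorine, a longer chain ending in chlorine, or a chain ending in an amine would keep a value in the same range on this carbonyl carbon. Also open is whether compound 1 and compound 3 would stay level on other cell lines, as all the numbers shown come from a single assay.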